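Trimming the Side Chain of Compound 1

A few compounds are considered here, and "the series" means these few. Any claim that something is new, unique, unknown or untested is made for them only; others in the source may bear on it.

Measured compounds in a functional assay on A549 cells (Homo sapiens) for antiproliferative activity, read by MTT assay, with a stated time of 72 h; a higher number here means a weaker inhibitor, a lower number a stronger inhibitor:
- compound 1, `COc1cc2c(Oc3ccc(NC(=O)c4cc(-c5ccc(F)cc5)on4)cc3)ccnc2cc1OCCCN1CCC(C)CC1`: 3340 nM
- compound 2, `COc1cc2c(Oc3ccc(NC(=O)c4nc(-c5ccc(F)cc5)no4)cc3)ccnc2cc1OCCCN1CCC(C)CC1`: 870 nM
- compound 3, `COc1cc2c(Oc3ccc(NC(=O)c4nnc(-c5ccc(F)cc5)o4)cc3)ccnc2cc1OCCCN1CCC(C)CC1`: 2730 nM

Among these three, compound 1 gives the highest number. Compound 3 sits closest to it, with a 1.2-fold lower number from compound 1 to compound 3 (0.09 log units; within the scatter), a gap that stays within the scatter. Compound 2 stands furthest from it, with a 3.8-fold lower number from compound 1 to compound 2 (0.58 log units; beyond the scatter). Between the other two the step is a 3.1-fold higher number from compound 2 to compound 3 (0.50 log units; beyond the scatter).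

Compound 4, `COc1cc2nccc(Oc3ccc(NC(=O)c4cc(-c5ccc(F)cc5)on4)cc3)c2cc1OC`, is not yet measured. It departs from compound 1 in a single place: hydrogen in place of 2-(4-methylpiperidin-1-yl)ethyl on a saturated chain carbon bound to an oxygen on an aromatic ring. Everything else, including the heteroaryl ring and the fluorophenyl group, is kept as in compound 1.

All three measured steps swap the five-membered heteroaryl ring that carries the fluorophenyl group; none touches the chain on the aromatic oxygen. So no measured step bears directly on the change from compound 1 to compound 4, and the expectation rests on the bare fact that compound 1 starts from 3340 nM. With nothing to point either way, compound 4 is expected to show a step of about a 1.5-fold higher number from compound 1 to compound 4 (0.18 log units; within the scatter), which may well fall within the scatter. The estimate for compound 4 in this assay is therefore 5000 nM, with a range from 1500 nM to 20000 nM.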

Compound 4, half-maximal inhibitory concentration: 40400 nM
Beside the measured number, compound 4's estimate is 8.1-fold (0.91 log units) below it; the whole stated range lies below it.
By their numbers in this assay, from the lowest: compound 2; then compounds 3 and 1 (each within the scatter of the next); then compound 4.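

In this assay, cutting the 3-(4-methylpiperidin-1-yl)propoxy group of compound 1 back to methoxy gives a 12-fold higher number from compound 1 to compound 4 (1.08 log units; beyond the scatter) and is the first change shown at this position rather than on the heteroaryl ring. This large step exceeds the biggest heteroaryl swap shown, which is a 3.8-fold lower number from compound 1 to compound 2 (0.58 log units; beyond the scatter) and runs in the opposite direction, so among these compounds the change at the chain produces the largest shift in the number. Nothing measured alongside these compounds explains why removing the chain has this effect.

Because the whole 2-(4-methylpiperidin-1-yl)ethyl piece leaves in one step, the compounds shown cannot separate what the 4-methylpiperidine ring contributes from what the saturated chain carrying it contributes. On these data alone, a shorter or longer chain, a morpholine or dimethylamine at the end of the chain, or a carboxylic acid there could help to separate them, and it also remains open whether cutting the chain back to methoxy would have a similar effect on compound 2 with its different heteroaryl ring.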